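The source may hold more compounds than are shown below. What is called first, only, known or untested is meant among the compounds shown, and "the series" means these compounds.

Working notes on a small nitroimidazole dithiocarbamate series tested in a toxicity assay on HeLa cells (Homo sapiens) for cytotoxicity, read by MTT assay, with a stated time of 24 h; a higher number here means a weaker inhibitor, a lower number a stronger inhibitor.

Compound 1 `Cc1ncc([N+](=O)[O-])n1CC(O)CSC(=S)N1CCN(c2cccc(Cl)c2)CC1` gives 1080000 nM in this assay. Compound 2 `Cc1ncc([N+](=O)[O-])n1CC(O)CSC(=S)N1CCN(C(=O)OC(C)(C)C)CC1` gives 689000 nM. Compound 3 `Cc1nc([N+](=O)[O-])cn1CC(O)CSC(=S)N1CCN(c2cccc(Cl)c2)CC1` gives 1740000 nM. The values of compound 1 and compound 2 lie within the scatter of each other, as do those of compound 1 and compound 3; the gap between compound 2 and compound 3 is the only one beyond it.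

Two single-point changes connect the measured compounds. From compound 1 to compound 2 the change is tert-butoxycarbonyl in place of 3-chlorophenyl on an amine nitrogen in a ring and it gives a 1.6-fold lower number from compound 1 to compound 2 (0.20 log units; within the scatter). From compound 1 to compound 3 the two cores differ as 2-methyl-4-nitro-1H-imidazol-1-yl in place of 2-methyl-5-nitro-1H-imidazol-1-yl on a saturated chain carbon, two bonds along the chain from an oxygen on a saturated carbon, giving a 1.6-fold higher number from compound 1 to compound 3 (0.21 log units; within the scatter).

Compound 4 `Cc1nc([N+](=O)[O-])cn1CC(O)CSC(=S)N1CCN(C(=O)OC(C)(C)C)CC1` is not yet measured. It carries the core of compound 3 and differs from it as tert-butoxycarbonyl in place of 3-chlorophenyl on an amine nitrogen in a ring. This is the same change as that from compound 1 to compound 2: the same group leaves, the same group enters, and the place is the same, an amine nitrogen in a six-membered non-aromatic ring with two nitrogens. The change has been seen once before among these compounds, and that one step lay within the scatter.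

The expectation for compound 4 is that replacing 3-chlorophenyl by tert-butoxycarbonyl on the core of compound 3 gives a step close to a 1.6-fold lower number from compound 3 to compound 4 (0.20 log units; within the scatter), because the same change gave a 1.6-fold lower number from compound 1 to compound 2 (0.20 log units; within the scatter) on the other core. On that basis compound 4 is estimated at 1090000 nM in this assay, with a plausible range from 600000 nM to 2000000 nM. The measured value is awaited.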

Compound 4, half-maximal inhibitory concentration: > 5000000 nM
Compound 4: a limit, no number; the forecaster's own chance of this, stated with the estimate: 10%; middle value at least 4.5-fold (0.66 log units) away from the limit.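

In this assay compound 4 gives > 5000000 nM, which is a limit and not a number. On the core of compound 3, tert-butoxycarbonyl in place of 3-chlorophenyl gives an at least 2.8-fold higher number from compound 3 to compound 4 (0.45 log units; beyond the scatter), and with tert-butoxycarbonyl held fixed, the change of core gives an at least 7.2-fold higher number from compound 2 to compound 4 (0.86 log units; beyond the scatter), so the group change does not carry from one core to the other at the size first seen: the same change on two cores in this assay, a 1.6-fold lower number (0.20 log units; within the scatter) from compound 1 to compound 2 and an at least 2.8-fold higher number (0.45 log units; beyond the scatter) from compound 3 to compound 4, at least 4.5-fold (0.65 log units) apart, beyond the scatter of two such steps The same non-additivity appears when the core change is read on the two groups, but it rests on a single pair of cores and a single pair of groups, and it fixes neither the true size of the gap nor any rule beyond these four compounds: the same change on two cores in this assay, a 1.6-fold higher number (0.21 log units; within the scatter) from compound 1 to compound 3 and an at least 7.2-fold higher number (0.86 log units; beyond the scatter) from compound 2 to compound 4, at least 4.5-fold (0.65 log units) apart, beyond the scatter of two such steps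

The compounds shown leave open whether the dependence on the core extends to other groups on the same amine nitrogen, such as an unsubstituted phenyl, an acetyl group or a short alkyl chain. They also leave open whether it persists when the hydroxyl on the saturated chain gives way to a ketone or a plain methylene.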